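The compounds below may be only part of what the source reports. "The series", "measured", "known", "first", "only" and "open" are said of these compounds alone.

Compound 1 `CNC(=O)/C=C/CNCCOc1ccc(Oc2c(-c3ccc(F)cc3)sc3cc(O)ccc23)cc1`: in a functional assay on MDA-MB-231 cells (Homo sapiens) for antiproliferative activity, read by CCK-8 assay, with a stated time of 48 h (a lower number here means a stronger inhibitor, a higher number a weaker inhibitor), compound 1 gives > 50000 nM, a limit of the assay.
Compound 2 `O=C(/C=C/CNCCOc1ccc(Oc2c(-c3ccc(F)cc3)sc3cc(O)ccc23)cc1)N1CCCCC1`: in this assay compound 2 gives > 50000 nM, a limit of the assay.
Compound 3 `O=C(/C=C/CNCCOc1ccc(Oc2c(-c3ccc(F)cc3)sc3cc(O)ccc23)cc1)N1CCCC1`: in this assay compound 3 gives > 50000 nM, a limit of the assay.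

Compound 2 thus stands at the limit, as do both other measured compounds, since (the limit of > 50000 nM in this assay, at which 3 of the 3 values shown sit). The step from compound 2 to compound 4 `O=C(/C=C/CNCCOc1ccc(Oc2c(-c3ccc(F)cc3)sc3cc(O)ccc23)cc1)N1CCC1` swaps the ring on the carbonyl: azetidin-1-yl in place of piperidin-1-yl on a carbonyl carbon. The closest measured step, a ring change at the same carbonyl, is a step that the two limits leave unreadable from compound 2 to compound 3; likewise a step that the two limits leave unreadable from compound 1 to compound 2 and a step that the two limits leave unreadable from compound 1 to compound 3 cannot be read. Among the compounds with values here, no measured step therefore points to any movement, and the expectation for compound 4 is another limit rather than a number. Compound 4 is estimated at 50000 nM, with a range from 20000 nM to 150000 nM. The expected step is a number no higher from compound 2 to compound 4 (the limit leaves the size open), nothing beyond the scatter.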

Compound 4, half-maximal inhibitory concentration: > 50000 nM
Compound 4 gave a limit, no number; the forecaster's own chance of this, stated with the estimate: 85%; the middle value lies on the limit itself.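

Within the data shown here, compound 4 gives only a limit, as do compound 1, compound 2 and compound 3, so no step among them can be read: the limit of > 50000 nM in this assay, at which 4 of the 4 values shown sit. These compounds leave open whether any group on the carbonyl carbon changes the activity at all.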